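Aromatic substituent change: nitro to acetamido in one series

This account rests on a few compounds, and the source may have more. Where it says the series, first, only, none or still open, it means among the compounds named here.

Measured so far:
compound 1 `CC(C)(C)C1=NN(c2ccc(Cl)cc2)C(c2ccc(Br)cc2)C1` — 39%
compound 2 `CC(C)(C)C1=NN(c2ccc(Cl)cc2)C(c2ccc([N+](=O)[O-])cc2)C1` — 0%

In an assay on isolated protein for inhibition of protein kinase C zeta type (Homo sapiens), with a stated time of 4 min, tested at 62.5 uM (a lower number here means less inhibition, a higher number more inhibition at the concentration tested (going by the name of the read-out)), compound 1 gives 39% and compound 2 gives 0%. Among the compounds with values here, compound 2 stands lowest of the two numbers; the single measured step, a number 39 percentage points lower from compound 1 to compound 2 (beyond the scatter), was large and beyond the scatter.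

Compound 3 `CC(=O)Nc1ccc(C2CC(C(C)(C)C)=NN2c2ccc(Cl)cc2)cc1` differs from compound 2 by acetamido in place of nitro on an aromatic carbon. Within the data shown here, the only measured step bears on this indirectly: it shows that the group on this aromatic carbon can move the read-out by a large amount, but no measured compound carries acetamido, so its direction rests on no direct precedent. Since compound 2 sits at the floor of the scale, the expected step of a number 15 percentage points higher from compound 2 to compound 3 (beyond the scatter) can hardly be downward; a small to moderate rise is expected, with wide uncertainty. For compound 3 the estimate in this assay is 15%, expected between 0% and 45%.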

Compound 3, a percentage reported as inhibition, at one concentration (the size of the read-out at that concentration, not a potency): 45.1%
Compound 3: the middle estimate sits 30.1 percentage points below what was measured; measured number outside the range, above it.
By their numbers in this assay, from the lowest: compound 2; then compounds 1 and 3 (each within the scatter of the next).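

In this assay the change to acetamido gives a number 45.1 percentage points higher from compound 2 to compound 3 (beyond the scatter) and so shows that this aromatic carbon, para to a large group, can take a substituent other than a halogen without the read-out falling to the level of the nitro compound. Set against bromo, the same group gives a number 6.1 percentage points higher from compound 1 to compound 3 (within the scatter) and the two cannot be told apart here, although acetamido carries a hydrogen-bond donor and bromo does not. Of the three groups, only nitro stands apart from the other two, and no measurement available here explains why the read-out responds this way.

As far as these compounds go, whether an amine, a carboxylic acid or a longer acyl chain on this carbon would stay level with acetamido and bromo remains open. Also open, from the compounds shown here alone, is whether the amide hydrogen matters, which a methylated amide would address.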